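Lengthening the Saturated Chain of Compound 2

The source may report more compounds than this note shows. Statements on the series, on what has been measured and on what is new or still open speak of the compounds shown alone.

- Compound 1 `CCCCCC1(c2ccccc2)NC(=O)N(C)C1=O`: 2.96
- Compound 2 `CCCCCCC1(c2ccccc2)NC(=O)NC1=O`: 3.4

Both numbers come from a physicochemical assay for lipophilicity; on this read-out lower numbers stand for lower lipophilicity and higher numbers for higher lipophilicity. Compound 2 stands highest of the pair at 3.4, while compound 1 lies lower at 2.96, a gap beyond the usual scatter of repeated measurements. Compound 3 `CCCCCCCCC1(c2ccccc2)NC(=O)NC1=O` has not yet been measured. It differs from compound 2 in one place: ethyl in place of hydrogen on a saturated chain carbon, six bonds along the chain from a saturated ring carbon. In words, this is ethyl in place of hydrogen on a saturated chain carbon, six bonds along the chain from a saturated ring carbon. For the measured compounds named here, no measured pair differs in one place only, so the data hold no direct measure of this change. Resting on the structural change alone, the expected step is a number 1.00 log units higher from compound 2 to compound 3 (beyond the scatter), upward and beyond the scatter. For compound 3 the estimated value is 4.4, with an expected range from 3.9 to 4.9.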

Compound 3, partition coefficient: 4.96
The estimate for compound 3 lay 0.56 log units below the measured number; measured number above the stated range.
By their numbers in this assay, from the lowest: compound 1; then compound 2; then compound 3.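

In this assay, ethyl in place of hydrogen on this saturated chain carbon gives a step of a number 1.56 log units higher from compound 2 to compound 3 (beyond the scatter), and this pair offers the first direct measure of a change in one place only. The step is large for a group of 2 heavy atoms, both carbon, with no ring, no hydrogen-bond donors or acceptors and no net charge. Nothing at hand explains why the step has this size.

This single pair cannot show whether a longer chain at the same place would bring a similar step, a smaller one or none. It also leaves open how an amine or a carboxylic acid on that same saturated chain carbon would compare with ethyl on this read-out.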